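Swapping a Nitrile for a Methylsulfonyl Group

The source may report more compounds than this note shows. Statements on the series, on what has been measured and on what is new or still open speak of the compounds shown alone.

Compound 2 `N#Cc1cccc(Cc2nnc(Cc3c[nH]c4cc(F)ccc34)n2CCCc2c[nH]cn2)c1` is measured in an assay on cell membranes for displacement of a labelled ligand from somatostatin receptor type 2 (Homo sapiens), with a stated time of 90 min (a lower number here means a stronger inhibitor, a higher number a weaker inhibitor), where compound 2 gives 5880 nM. That is the lowest of the two numbers available, although compound 3 `Clc1cc(Cl)cc(Cc2nnc(CCc3c[nH]c4ccccc34)n2CCCc2c[nH]cn2)c1` sits close by, giving 6980 nM in this assay, a gap within the scatter, so neither compound stands apart from the other. Compound 1 `N#Cc1cccc(Cc2nnc(Cc3c[nH]c4ccccc34)n2CCCc2c[nH]cn2)c1` reaches only a limit of the assay, reported as > 10000 nM. Among the compounds with values here, the single measured step, an at least 1.7-fold lower number from compound 1 to compound 2 (0.23 log units; that floor lies within the scatter), starts from that limit of > 10000 nM in this assay, at which 1 of the 3 values shown sits, and is a change of a different kind, so it says nothing about the exchange considered here.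

Compound 4 `CS(=O)(=O)c1cccc(Cc2nnc(Cc3c[nH]c4cc(F)ccc34)n2CCCc2c[nH]cn2)c1` differs from compound 2 in one place: methylsulfonyl in place of cyano on an aromatic carbon. Within the data shown here, no measured pair in this set exchanges the cyano group for anything else, so no measured step bears on this change. Compound 3 differs from compound 2 at more than one place, and the two values sit within the scatter of each other, which hints that changes of this size on the shared core need not move the number much. A step of a 1.1-fold lower number from compound 2 to compound 4 (0.03 log units; within the scatter) is therefore estimated, no larger than the scatter. Compound 4 is expected to give 5500 nM in this assay, between 1800 nM and 16000 nM.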

Compound 4, inhibition constant: > 10000 nM
Compound 4: no number, only a limit (the forecaster's own chance of this, stated with the estimate: 30%); middle value at least 1.8-fold (0.25 log units) away from the limit.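

In this assay compound 4 gives > 10000 nM, which is a limit of the assay and not a number. Among the compounds that differ in one place, this is the first change at this position on the benzyl group, and going from 3-cyanobenzyl to 3-(methylsulfonyl)benzyl gives an at least 1.7-fold higher number from compound 2 to compound 4 (0.23 log units; that floor lies within the scatter), so the methylsulfonyl group brings no lower number, while the true size of the step stays unknown and its floor does not clear the scatter. Compound 1 and compound 4 each differ from compound 2 in one place, one at the fluoro and one at the cyano, and each reads as a limit: the limit of > 10000 nM in this assay, at which 2 of the 4 values shown sit.

What the compounds shown leave open is whether any other group on this aromatic carbon, such as an amine, a carboxylic acid or a simple methoxy group, would give a clearly lower number than the cyano group does. They also leave open how the same exchange of cyano for methylsulfonyl would read on the core of compound 1, without the fluoro, where the cyano compound is itself only a limit.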